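This account rests on a few compounds, and the source may have more. Where it says the series, first, only, none or still open, it means among the compounds named here.

The compounds here share one core and differ in the group it carries, and the property followed is a physicochemical assay for solubility, read by HPLC, in phosphate buffer, measured as kinetic solubility, at pH 7.4; a higher number here means a more soluble compound, a lower number a less soluble compound. Compound 1 `CCC(=O)c1cc(-c2ccccc2)n(-c2ccc(S(N)(=O)=O)cc2)c1C` gives 14100 nM. Compound 2 `CCC(=O)c1cc(-c2ccc(F)cc2)n(-c2ccc(S(N)(=O)=O)cc2)c1C`, which carries 4-fluorophenyl, gives 29300 nM. Compound 3 `CCC(=O)c1cc(-c2cccc(Cl)c2)n(-c2ccc(S(N)(=O)=O)cc2)c1C`, which carries 3-chlorophenyl, gives 12600 nM. This places compound 3 level with compound 1 and clearly under compound 2.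

Three measured steps offer guidance. Chloro in place of hydrogen gave a 1.1-fold lower number from compound 1 to compound 3 (0.05 log units; within the scatter), so that swap alone shifted nothing measurable. Fluoro in place of hydrogen gave a 2.1-fold higher number from compound 1 to compound 2 (0.32 log units; beyond the scatter), the only step here that goes up. Exchanging 4-fluorophenyl for 3-chlorophenyl gave a 2.3-fold lower number from compound 2 to compound 3 (0.37 log units; beyond the scatter).

The next compound is compound 4 `CCC(=O)c1cc(-c2ccc(Cl)cc2Cl)n(-c2ccc(S(N)(=O)=O)cc2)c1C`, in which 2,4-dichlorophenyl takes the place of 3-chlorophenyl: 2,4-dichlorophenyl in place of 3-chlorophenyl on an aromatic carbon. Going by the values given here, no measured compound carries this group, so the steps above are only a rough guide. The largest step among them, a 2.3-fold lower number from compound 2 to compound 3 (0.37 log units; beyond the scatter), ended on a chloro compound and went down, which points to a modest fall in this assay rather than a large one. The expected change is a 2.3-fold lower number from compound 3 to compound 4 (0.36 log units; beyond the scatter). For compound 4 the estimated value is 5500 nM, with an expected range of 1800 nM to 14000 nM.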

Compound 4, solubility: 7700 nM
Compound 4: middle estimate off by 1.4-fold (0.15 log units), on the low side; measured number inside the range.
By their numbers in this assay, from the lowest: compounds 4, 3 and 1 (each within the scatter of the next); then compound 2.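

In this assay, going by these compounds alone, the 2,4-dichlorophenyl group on the aromatic carbon next to the ring nitrogen gives a 1.6-fold lower number from compound 3 to compound 4 (0.21 log units; within the scatter) and, set against plain phenyl, a 1.8-fold lower number from compound 1 to compound 4 (0.26 log units; within the scatter), so neither comparison separates it from the earlier compounds. Only against the fluoro compound does a clear gap appear, with a 3.8-fold lower number from compound 2 to compound 4 (0.58 log units; beyond the scatter), now the largest step in this small set. Compound 2 therefore stands alone, while the phenyl, 3-chlorophenyl and 2,4-dichlorophenyl compounds sit at one level within the scatter of each other, and no supporting measurement is available to explain this pattern.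

As far as these compounds go, what 4-chlorophenyl or 3-fluorophenyl would give remains open, so the higher number of compound 2 cannot yet be tied to the fluoro group itself or to where it sits on the phenyl ring. Also open, from the compounds shown here alone, is whether an amine or a carboxylic acid on this phenyl ring, or a longer chain in place of the propanoyl group, would move the number beyond the range these four compounds span.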